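The compounds below may be only part of what the source reports. "The series", "measured", "known", "first", "only" and "open" are said of these compounds alone.

In a functional assay on MGC-803 cells (Homo sapiens) for antiproliferative activity, read by MTT assay, with a stated time of 72 h (a lower number here means a stronger inhibitor, a higher number a weaker inhibitor), two compounds sharing one core have been measured. Compound 1 (`CCCSc1nc(N/N=C/c2cccnc2)c2nnn(Cc3ccccc3)c2n1`) gives 38100 nM, and compound 2 (`CCCSc1nc(N/N=C/c2ccccc2Cl)c2nnn(Cc3ccccc3)c2n1`) gives 10900 nM, the lower of the two numbers. Among the compounds with values here, the single step between them is a 3.5-fold lower number from compound 1 to compound 2 (0.54 log units; beyond the scatter). It places 2-chlorophenyl in place of pyridin-3-yl on a carbon with a double bond to nitrogen, and it is modest, though beyond the scatter.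

Compound 3 (`CCCSc1nc(N/N=C/c2ccc(Cl)cc2)c2nnn(Cc3ccccc3)c2n1`) has the same atoms as compound 2, joined differently: 4-chlorophenyl in place of 2-chlorophenyl on a carbon with a double bond to nitrogen. Within the data shown here, no measured step exchanges one chlorophenyl group for another, so the data offer no direct precedent. The step of a 3.5-fold lower number from compound 1 to compound 2 (0.54 log units; beyond the scatter) bears on the question only indirectly, as a replacement of a different kind on the same carbon. The change here keeps the counted make-up of the group, so a shift no larger than that modest step is expected in this assay, possibly none beyond the scatter, and the data give no firm direction. The expected change is a 1.1-fold lower number from compound 2 to compound 3 (0.04 log units; within the scatter). For compound 3 the estimated value is 10000 nM, with an expected range from 3500 nM to 28000 nM.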

Compound 3, half-maximal inhibitory concentration: > 64000 nM
Compound 3: a limit, no number (the forecaster's own chance of this, stated with the estimate: 5%); at least 6.4-fold (0.80 log units) between middle value and limit.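

In this assay compound 3 gives no number, only a limit of the assay: the limit of > 64000 nM in this assay, at which 1 of the 3 values shown sits.

Within the data shown here, the earlier compounds showed only that one group could be replaced by another of a different make-up, whereas this result shows that the number can also shift when the counted make-up stays the same: 4-chlorophenyl in place of 2-chlorophenyl on a carbon with a double bond to nitrogen gives an at least 5.8-fold higher number from compound 2 to compound 3 (0.76 log units; beyond the scatter). Carrying a chlorine on the phenyl group is therefore not enough on its own to give the lower number of compound 2, and the comparison with the pyridin-3-yl group of compound 1 remains unsettled, at an at least 1.6-fold higher number from compound 1 to compound 3 (0.22 log units; that floor lies within the scatter).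

From the compounds shown here alone, how far compound 3 lies past its limit stays unknown, so the full size of both new steps cannot be read. Going by these compounds, it also remains open how a plain phenyl group, or a phenyl group carrying a fluorine or a methoxy group, would behave at this place, and whether a longer chain in place of the propyl chain on the shared core would alter the picture.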